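The compounds below may be only part of what the source reports. "The series", "measured", "known", "first", "only" and "open" are said of these compounds alone.

Measured so far in a functional assay on CHOK cells for antagonist activity at growth hormone secretagogue receptor type 1 (Homo sapiens), read by calcium flux; on this read-out higher numbers stand for weaker inhibition and lower numbers for stronger inhibition:

compound 1, `CCc1nc(N)nc(N)c1-c1ccc(NCc2cc(F)c(S(=O)(=O)C(F)(F)F)c(F)c2)cc1`: 690 nM
compound 2, `Nc1nc(N)c(-c2ccc(NCc3cc(F)c(S(=O)(=O)C(F)(F)F)c(F)c3)cc2)c(COCc2ccccc2)n1`: 85 nM
compound 3, `Nc1nc(N)c(-c2ccc(CNc3ccc([N+](=O)[O-])cc3)cc2)c(COCc2ccccc2)n1`: 16 nM

Compound 3 has the lowest number of the three; compound 2 stands nearest to it and compound 1 furthest, both gaps beyond the scatter. Compound 2 and compound 3 differ in more than one place, and the difference between the two cores is not broken down here.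

One change recurs twice in the set. From compound 2 to compound 1 it reads methyl in place of benzyloxy on a saturated chain carbon bound to an aromatic carbon and gave an 8.1-fold higher number from compound 2 to compound 1 (0.91 log units; beyond the scatter) in this assay. From compound 3 to the unmeasured compound 4, `CCc1nc(N)nc(N)c1-c1ccc(CNc2ccc([N+](=O)[O-])cc2)cc1`, the computed difference reads (methyl in place of benzyloxy on a saturated chain carbon bound to an aromatic carbon), and the place of the change is the same word for word in both pairs.

Compound 4 is therefore expected to sit higher than compound 3 in this assay, with a step of about an 8.1-fold higher number from compound 3 to compound 4 (0.91 log units; beyond the scatter), the expectation resting on compound 2 to compound 1 having shown an 8.1-fold higher number from compound 2 to compound 1 (0.91 log units; beyond the scatter) for the identical change. Among the compounds with values here, since the pair is only one example and the surrounding core differs, the step may not carry over exactly, so the range is kept wide. Compound 4 is estimated at 130 nM in this assay, with an expected span from 45 nM to 400 nM.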

Compound 4, half-maximal inhibitory concentration: 190 nM
For compound 4 the middle estimate is 1.5-fold (0.16 log units) below the measured one; the range from low to high includes it.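

In this assay, methyl in place of benzyloxy on a saturated chain carbon bound to an aromatic carbon gave a 12-fold higher number from compound 3 to compound 4 (1.07 log units; beyond the scatter) on the core shared by compound 3 and compound 4. Within the data shown here, this result rests on only two cores, so it does not show that the change would behave in the same way on any further core, and it gives no reason why the numbers rise when benzyloxy leaves. Within those limits, the change carried from one core to the other with no difference in step size that can be told apart from the scatter, and both pairs point the same way: the same change on two cores in this assay, an 8.1-fold higher number (0.91 log units; beyond the scatter) from compound 2 to compound 1 and a 12-fold higher number (1.07 log units; beyond the scatter) from compound 3 to compound 4, 1.5-fold (0.17 log units) apart, within the scatter of two such steps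

Only benzyloxy and methyl stand at this place on both cores, so the compounds shown leave open which part of benzyloxy matters, the carbon-only aromatic ring or the oxygen, and a methoxy group or a plain benzyl group would separate the two. Also open, on these data alone, is how the series responds at this place to other kinds of group, such as a longer chain, an amine or a carboxylic acid, and whether either core would tolerate them equally.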